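Two fluoro groups and a dimethylpiperazine

The source may hold more compounds than are shown below. What is called first, only, known or untested is meant among the compounds shown, and "the series" means these compounds.

Measured in a physicochemical assay for solubility, read by HPLC, using the shake flask method, in phosphate buffer, measured as kinetic solubility, with a stated time of 20 h, at pH 6.5; a lower number here means a less soluble compound, a higher number a more soluble compound:
- compound 1 `Fc1ccc(Nc2cc3[nH]c(Nc4ccc(N5CCNCC5)cn4)nc3cn2)cc1C(F)(F)F` gives 180000 nM
- compound 2 `Fc1ccc(Nc2cc3[nH]c(Nc4cc(N5CCNCC5)ccn4)nc3cn2)cc1C(F)(F)F` gives 95000 nM
- compound 3 `Fc1ccc(Nc2cc3[nH]c(Nc4ccc(N5CCNCC5)cn4)nc3cn2)cc1F` gives < 5000 nM, which is a limit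

Compound 3 stands at the limit of < 5000 nM in this assay, at which 1 of the 3 values shown sits. Compound 4 `C[C@@H]1CN(c2ccc(Nc3nc4cnc(Nc5ccc(F)c(F)c5)cc4[nH]3)nc2)C[C@H](C)N1` differs from compound 3 in one place, with 3,5-dimethylpiperazin-1-yl in place of piperazin-1-yl on an aromatic carbon.

Only one measured step links two of these compounds, an at least 36-fold lower number from compound 1 to compound 3 (1.55 log units; beyond the scatter). That step is large, but it is a different change, with fluoro in place of trifluoromethyl. It bears on compound 4 only by setting the starting point, since compound 4 carries the same groups as compound 3 at that site. Going by the values given here, no measured step touches the piperazin-1-yl group, so no step beyond the scatter is expected in this assay, in either direction.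

The expected step is a step that the limit leaves unreadable from compound 3 to compound 4. The estimated value for compound 4 is 3000 nM, with an expected range from 800 nM to 10000 nM.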

Compound 4, solubility: 175000 nM
Compound 4: the middle estimate sits 58-fold (1.77 log units) below what was measured; the whole stated range lies below it.
By their numbers in this assay, from the lowest: compounds 2, 4 and 1 (each within the scatter of the next). At a limit, below all of these: compound 3.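

On the six-membered aromatic ring with 1 nitrogen, where every earlier compound carried piperazin-1-yl, the change to 3,5-dimethylpiperazin-1-yl gives in this assay an at least 35-fold higher number from compound 3 to compound 4 (1.54 log units; beyond the scatter), so this site can move the number strongly. Hydrogen-bond donors, hydrogen-bond acceptors and net charge count the same for both groups, while the entering group has more heavy atoms and 2 defined stereocentres. The true size of the step stays unknown, because compound 3 stands at a limit: the limit of < 5000 nM in this assay, at which 1 of the 4 values shown sits.

The compounds shown leave open whether a single methyl on the piperazine, or another stereoisomer of the dimethylpiperazine, would give a similar number. They also leave open how a morpholine or an open-chain amine would behave at this place, and what the dimethylpiperazine would do alongside the trifluoromethyl group of compound 1.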